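Propoxy in place of tert-butyl: working notes

The compounds below may be only part of what the source reports. "The series", "measured", "known", "first", "only" and "open" are said of these compounds alone.

Measured in a functional assay on HT-29 cells (Homo sapiens) for cytotoxicity; a lower number here means that less compound is needed, a higher number that more compound is needed for the effect:
- compound 1 `CCOc1ccc(/C=C/c2cc(OC)c(OC)c(OC)c2)cc1` gives 1.49 uM 
- compound 2 `COc1cc(/C=C/c2ccc(C(C)(C)C)cc2)cc(OC)c1OC` gives > 25 uM 

Compound 2 stands at the limit of > 25 uM in this assay, at which 1 of the 2 values shown sits, and so has a limit and not a number. Compound 3 `CCCOc1ccc(/C=C/c2cc(OC)c(OC)c(OC)c2)cc1` brings propoxy in place of tert-butyl on an aromatic carbon with propoxy in place of tert-butyl on an aromatic carbon as the counted difference. For the measured compounds named here, one measured step bears on this, with tert-butyl in place of ethoxy: an at least 16-fold higher number from compound 1 to compound 2 (1.22 log units; beyond the scatter) and that step is large. Reversing it with propoxy, a large move to a lower number is expected in this assay with its size left open by the limit. The expected change is an at least 10-fold lower number from compound 2 to compound 3 (1.00 log units; beyond the scatter) as estimated here. Compound 3 is estimated at 2.5 uM with an expected range from 0.6 uM to 10 uM in this assay.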

Compound 3, concentration for half-maximal effect: > 25 uM
Compound 3 ended at the assay's limit; the forecaster's own chance of this, stated with the estimate: 8%; middle value at least 10-fold (1.00 log units) away from the limit.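

A single added methyl on the chain is enough for a large change in this assay, with an at least 16-fold higher number from compound 1 to compound 3 (1.22 log units; beyond the scatter). Propoxy keeps the oxygen on the ring that tert-butyl lacks, so that oxygen alone does not hold the number near that of compound 1. The step between compound 2 and compound 3 cannot be read: the limit of > 25 uM in this assay, at which 2 of the 3 values shown sit.

Going by these compounds, how far compound 2 and compound 3 lie past that limit stays open. Also open, on these data alone, is whether a hydroxy group or an amine at this place would match or improve on compound 1.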